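A few compounds are considered here, and "the series" means these few. Any claim that something is new, unique, unknown or untested is made for them only; others in the source may bear on it.

Measured compounds:
- compound 1 `COc1ccc(OC)c(Sc2ccc3nnc(-c4cccnc4)n3n2)c1` gives 242 nM
- compound 2 `COc1ccc(OC)c(Sc2ccc3nnc(-c4cnccn4)n3n2)c1` gives 880 nM
- compound 3 `COc1ccc(OC)c(Sc2ccc3nnc(C4CCN(C)C4)n3n2)c1` gives 12600 nM

All three numbers come from an assay on isolated protein for inhibition of Leucine-rich repeat serine/threonine-protein kinase 2 (Homo sapiens), in the presence of a further agent that is not named here; on this read-out lower numbers stand for stronger inhibition and higher numbers for weaker inhibition. On that read-out compound 3 stands with the highest number of the three: the step from compound 1 is a 52-fold higher number from compound 1 to compound 3 (1.72 log units; beyond the scatter) and the step from compound 2 is a 14-fold higher number from compound 2 to compound 3 (1.16 log units; beyond the scatter), both beyond the scatter. Between compound 1 and compound 2 the step is a 3.6-fold higher number from compound 1 to compound 2 (0.56 log units; beyond the scatter).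

Compound 4 `COc1ccc(OC)c(Sc2ccc3nnc(-c4cn(C)nc4C)n3n2)c1` has not been measured in this assay. It differs from compound 3 in one place: 1,3-dimethyl-1H-pyrazol-4-yl in place of 1-methylpyrrolidin-3-yl on an aromatic carbon. Within the data shown here, two measured steps bear on this change. Both steps into compound 3, from compound 1 and from compound 2, replaced a six-membered aromatic ring carrying ring nitrogen with the 1-methylpyrrolidin-3-yl group and gave large rises in the number. The change to compound 4 reverses that type of move, putting a five-membered aromatic ring with 2 hetero atoms and 2 hydrogen-bond acceptors in the same place. The expectation is therefore a large fall in the number in this assay, roughly of the order seen in those two steps. The range is kept wide: the entering ring matches neither the pyridin-3-yl of compound 1 nor the pyrazin-2-yl of compound 2. Compound 4 is estimated at 600 nM, with a range from 150 nM to 2500 nM. The expected step is a 21-fold lower number from compound 3 to compound 4 (1.32 log units; beyond the scatter).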

Compound 4, half-maximal inhibitory concentration: 323 nM
Estimate against measurement, compound 4: 1.9-fold (0.27 log units) above; measured number inside the range.
By their numbers in this assay, from the lowest: compounds 1 and 4 (each within the scatter of the next); then compound 2; then compound 3.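

Working notes on the series: in this assay, the position on an aromatic carbon between two ring nitrogen atoms accepts a five-membered aromatic ring as well as the six-membered aromatic rings of compound 1 and compound 2, as a 39-fold lower number from compound 3 to compound 4 (1.59 log units; beyond the scatter) shows for 1,3-dimethyl-1H-pyrazol-4-yl in place of 1-methylpyrrolidin-3-yl. Among these compounds, the pyrazole cannot be told apart from pyridin-3-yl, with a 1.3-fold higher number from compound 1 to compound 4 (0.13 log units; within the scatter), yet a 2.7-fold lower number from compound 2 to compound 4 (0.44 log units; beyond the scatter) separates it from pyrazin-2-yl, so the three aromatic groups do not behave as one and compound 2 remains apart from compound 1 and compound 4, while compound 3, the only one with a non-aromatic ring, has the highest number. Nothing measured accounts for any of these steps.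

Open, going by these compounds, is how much of the result belongs to the two methyl groups of the pyrazole, a question that the plain 1H-pyrazol-4-yl group or its 1-methyl analogue would address. Also open, on these data alone, is whether the non-aromatic ring as such or its ring nitrogen goes with the high number of compound 3, which a cyclopentyl or tetrahydrofuran-3-yl group at the same place would help to separate.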